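Replacing a side group on compound 2

The source may hold more compounds than are shown below. What is called first, only, known or untested is meant among the compounds shown, and "the series" means these compounds.

- compound 1 (`COC(=O)[C@@H]1CCCN1C(=O)CCC(=O)Oc1ccc(C[C@H]2C(=O)OC[C@@H]2Cc2ccc(OC)c(OC)c2)cc1OC`) gives 145000 nM
- compound 2 (`CCN(CC)C(=O)CCC(=O)Oc1ccc(C[C@H]2C(=O)OC[C@@H]2Cc2ccc(OC)c(OC)c2)cc1OC`) gives 213000 nM
- compound 3 (`COC(=O)[C@@H](NC(=O)CCC(=O)Oc1ccc(C[C@H]2C(=O)OC[C@@H]2Cc2ccc(OC)c(OC)c2)cc1OC)C(C)C`) gives 64000 nM

These values come from an ADME assay on HeLa cells (Homo sapiens) for cytotoxicity, read by MTT assay (on this read-out higher numbers stand for weaker inhibition and lower numbers for stronger inhibition), and differ little. Compound 2 (213000 nM) lies close to one neighbour, with a 1.5-fold higher number from compound 1 to compound 2 (0.17 log units; within the scatter) as the step, and further from the other, with a 3.3-fold lower number from compound 2 to compound 3 (0.52 log units; beyond the scatter) as the step.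

Compound 4 (`COc1ccc(C[C@H]2COC(=O)[C@@H]2Cc2ccc(OCC(=O)N3CCCC3)c(OC)c2)cc1OC`) has not yet been measured in this assay and differs from compound 2 in one place: a group of 8 heavy atoms (6 carbon, 1 nitrogen, 1 oxygen; one five-membered non-aromatic ring with 1 hetero atom) in place of a group of 11 heavy atoms (8 carbon, 1 nitrogen, 2 oxygen; no ring), on an oxygen on an aromatic ring. The entering group is ((pyrrolidin-1-yl)carbonyl)methyl.

The measured steps bear on this only in part. Each swaps a group on a carbonyl carbon, and none replaces the whole group on the oxygen on the aromatic ring. They remain modest or smaller: a 1.5-fold higher number from compound 1 to compound 2 (0.17 log units; within the scatter) and a 2.3-fold lower number from compound 1 to compound 3 (0.36 log units; beyond the scatter) as well as a 3.3-fold lower number from compound 2 to compound 3 (0.52 log units; beyond the scatter). On that basis no step beyond the scatter is expected, and the expected step is a 1.6-fold lower number from compound 2 to compound 4 (0.21 log units; within the scatter). For compound 4 the estimated value is 130000 nM (expected range 45000 nM to 320000 nM).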

Compound 4, half-maximal inhibitory concentration: >= 600000 nM
Compound 4: no number, only a limit (the forecaster's own chance of this, stated with the estimate: 15%); middle value at least 4.6-fold (0.66 log units) away from the limit.
By their numbers in this assay, from the lowest: compound 3; then compounds 1 and 2 (each within the scatter of the next). At a limit, above all of these: compound 4.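

In this assay compound 4 gives >= 600000 nM, which is a limit of the assay and not a number. Replacing the whole group on the oxygen on an aromatic ring with ((pyrrolidin-1-yl)carbonyl)methyl gives an at least 2.8-fold higher number from compound 2 to compound 4 (0.44 log units; beyond the scatter), so this position can move the read-out towards weaker inhibition, a change that the earlier swaps on a carbonyl carbon could not show. The full size of that step stays unknown, as the reading ends at a limit: the limit of >= 600000 nM in this assay, at which 1 of the 4 values shown sits.

The compounds shown do not separate the effect of the pyrrolidine ring from that of the change in the rest of the group. Going by these compounds, how a carboxylic acid, an amine or a longer chain on this oxygen would read also remains open.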